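Methylsulfanyl to amino on a purine-type inhibitor core

The source may report more compounds than this note shows. Statements on the series, on what has been measured and on what is new or still open speak of the compounds shown alone.

Measured compounds:
compound 1, `Clc1cccc(Nc2nc(Cl)nc3[nH]cnc23)c1`: 3900 nM
compound 2, `COc1cccc(Nc2nc(SC)nc3[nH]cnc23)c1`: > 100000 nM
compound 3, `Fc1cccc(Nc2nc(Cl)nc3[nH]cnc23)c1`: 7500 nM

Of the compounds shown here, three share one core and have been measured in an assay for inhibition of cytokinin dehydrogenase 2 (Arabidopsis thaliana); a lower number here means a stronger inhibitor, a higher number a weaker inhibitor. Compound 1 carries a chloro group on the aniline ring and gives 3900 nM. Within the data shown here, compound 3 differs from it only in a fluoro group in that position and gives 7500 nM; the step of a 1.9-fold higher number from compound 1 to compound 3 (0.28 log units; within the scatter) is the only step so far between two compounds that differ in a single place. Among the measured compounds shown here, compound 2 stands apart: its result in this assay is not a number but a limit, > 100000 nM, the one value among the three that sits at the limit of > 100000 nM in this assay, at which 1 of the 3 values shown sits.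

Compound 4, `COc1cccc(Nc2nc(N)nc3[nH]cnc23)c1`, has not yet been measured. It differs from compound 2 by amino in place of methylsulfanyl on an aromatic carbon: the methylsulfanyl group leaves and an amino group enters, on an aromatic carbon between two ring nitrogen atoms of the fused core. For the measured compounds named here, no measured step touches that position; the step of a 1.9-fold higher number from compound 1 to compound 3 (0.28 log units; within the scatter) concerns the aniline ring and cannot speak to it. The expectation for compound 4 therefore rests on the limit of compound 2 alone and is wide. In this assay compound 4 is estimated at 50000 nM, within 5000 nM to 300000 nM, which would mean an expected step of an at least 2.0-fold lower number from compound 2 to compound 4 (0.30 log units; that floor lies within the scatter).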

Compound 4, half-maximal inhibitory concentration: 27000 nM
The estimate for compound 4 lay 1.9-fold (0.27 log units) above the measured number; low and high end bracket the measured number.
By their numbers in this assay, from the lowest: compounds 1 and 3 (each within the scatter of the next); then compound 4. At a limit, above all of these: compound 2.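

In this assay, among these compounds, the change from methylsulfanyl to amino gives the first reading at this aromatic carbon between two ring nitrogen atoms: an at least 3.7-fold lower number from compound 2 to compound 4 (0.56 log units; beyond the scatter). Unlike the exchange of chloro for fluoro on the aniline ring, which stayed within the scatter, this step lies beyond it, so the group on this carbon does affect the result, although compound 4 still gives only 27000 nM. The upper size of the step remains unknown, as compound 2 is known only through a limit of the assay: the limit of > 100000 nM in this assay, at which 1 of the 4 values shown sits.

The compounds shown leave open whether the step comes from the hydrogen-bond donor that amino brings or simply from the departure of methylsulfanyl, a question that a methylamino group, a hydroxy group or a plain hydrogen on this carbon could help to settle. They also leave open how amino compares with the chloro group of compound 1 and compound 3, as no pair shown carries those two groups on the same aniline ring.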